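The source may hold more compounds than are shown below. What is called first, only, known or untested is meant among the compounds shown, and "the series" means these compounds.

Working notes on the series. In a functional assay on HepG2 cells (Homo sapiens) for antiproliferative activity, read by MTT assay, with a stated time of 72 h (on this read-out higher numbers stand for weaker inhibition and lower numbers for stronger inhibition), compound 1 (`COc1ncc(-c2ccc3c(c2)N(c2ccc(C)cc2)C(=O)CO3)cc1NS(=O)(=O)c1ccc(F)cc1`) gives 28300 nM as its reading and compound 2 (`CC(C)N1C(=O)COc2ccc(-c3cnc(Cl)c(NS(=O)(=O)c4ccc(F)cc4)c3)cc21`) gives 21500 nM as its reading. These two numbers lie within the scatter of each other, so compound 2 stands level with compound 1.

The next compound is compound 3 (`O=C1COc2ccc(-c3cnc(Cl)c(NS(=O)(=O)c4ccc(F)cc4)c3)cc2N1c1ccc(Cl)cc1`), which has 4-chlorophenyl in place of isopropyl on an amide-type nitrogen in a ring and otherwise matches compound 2. For the measured compounds named here, the series offers no measured step between compounds that differ in one place, so this change has no direct precedent in this assay and the expectation rests on the two readings alone. Both fall within the scatter of each other, so no step beyond the scatter is expected, with only a slight lean toward a lower number. The estimated move is a 1.4-fold lower number from compound 2 to compound 3 (0.16 log units; within the scatter) as a middle figure, and it is expected to stay within the scatter. With so little to go on, the range is kept wide. Compound 3 is estimated at 15000 nM in this assay with an expected range from 5000 nM to 40000 nM for a single measurement.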

Compound 3, half-maximal inhibitory concentration: 33900 nM
Compound 3: the middle estimate sits 2.3-fold (0.35 log units) below what was measured, within the range that was stated.
By their numbers in this assay, from the lowest: compounds 2, 1 and 3 (each within the scatter of the next).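

In this assay, for the compounds shown here, the exchange of isopropyl for 4-chlorophenyl on the amide-type nitrogen in a ring gives a 1.6-fold higher number from compound 2 to compound 3 (0.20 log units; within the scatter) and is the first change that can be read at a single place. At this nitrogen, therefore, an open branched alkyl group and a chlorinated aromatic ring of carbon only give readings that cannot be told apart, and adding a ring here does not separate compound 3 from compound 2 on this read-out. No measurement of any property of these compounds bears on this result, so the step stands as a bare observation.

Still open, going by these compounds, is whether any group at this nitrogen can move the reading beyond the scatter, for instance a chain ending in an amine, a carboxylic acid, or a plain phenyl that would show whether the chlorine of the 4-chlorophenyl counts for anything. Compound 1 differs from compound 2 and from compound 3 in more than one place, so the roles of its methoxy group and its 4-methylphenyl group cannot be read separately from these compounds.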